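Isopropyl in place of phenyl on a core without measured potency

The source may report more compounds than this note shows. Statements on the series, on what has been measured and on what is new or still open speak of the compounds shown alone.

Measured compounds:
compound 1, `CCCc1nc(C)c2c(-c3ccccc3)nnc(SC)n12`: > 48000 nM
compound 2, `CCCc1nc(C)c2c(-c3ccccc3)nnc(O)n12`: > 48000 nM

The assay is a functional assay for inhibition, with Homo sapiens as the target; a higher number here means a weaker inhibitor, a lower number a stronger inhibitor. Compound 1 reaches only the limit of this assay, > 48000 nM, so no number stands for it. Compound 2 likewise sits at the limit, > 48000 nM. Both values therefore rest at the same boundary, (the limit of > 48000 nM in this assay, at which 2 of the 2 values shown sit), and the step that the two limits leave unreadable from compound 1 to compound 2, hydroxy in place of methylsulfanyl on an aromatic carbon, cannot be read in size or direction.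

Compound 3, `CCCc1nc(C)c2c(C(C)C)nnc(SC)n12`, differs from compound 1 by isopropyl in place of phenyl on an aromatic carbon. For the measured compounds named here, no measured step touches this position; the single measured step concerns another group and is itself unreadable. Nothing measured thus points to a gain in potency for the isopropyl compound, and the two limits give no foothold for a drop either.

Compound 3 is therefore expected to stay near the limit, with an expected step that the limit leaves unreadable from compound 1 to compound 3 in this assay. The estimate for compound 3 is 70000 nM, with a range from 20000 nM to 250000 nM.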

Compound 3, half-maximal inhibitory concentration: > 48000 nM
Compound 3: no number, only a limit; the forecaster's own chance of this, stated with the estimate: 85%; the middle value lies beyond the limit too.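

No step can be read from compound 1 to compound 3, because both stop at the same boundary: the limit of > 48000 nM in this assay, at which 3 of the 3 values shown sit. The compounds shown leave open how strongly any of them inhibits in this assay and whether isopropyl or phenyl on this aromatic carbon makes any difference to potency on the shared core.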